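The compounds below may be only part of what the source reports. "The series", "measured", "known", "first", "only" and "open" are said of these compounds alone.

Compound 1 `COc1ccc(NCCNC(=O)[C@@H](NC(=O)c2cccc(C)c2)C2CCCCC2)cc1` holds the higher of the two measured numbers in an assay on isolated protein for inhibition of cathepsin S (Homo sapiens), at 37 degrees C, at pH 5.5 (on this read-out higher numbers stand for weaker inhibition and lower numbers for stronger inhibition), where compound 1 gives 23 nM. Compound 2 `COc1ccc(NCCNC(=O)[C@H](CC2CCCCC2)NC(=O)c2ccc(Nc3nc(C)cc(C)n3)cc2)cc1` gives 2 nM in this assay; its structure differs from compound 1 in more than one place, and only the two values themselves are set side by side here. Compound 3 `COc1ccc(NCCNC(=O)[C@H](CC(C)(C)C)NC(=O)c2cccc(C)c2)cc1` carries neopentyl in place of cyclohexyl on a saturated chain carbon bound to an amide-type nitrogen and a carbonyl carbon. Within the data shown here, no measured pair isolates this change, and the step from compound 1 to compound 3 is expected to be small, a 1.7-fold higher number from compound 1 to compound 3 (0.24 log units; within the scatter), toward a somewhat higher number that may stay within the scatter. Compound 3 is accordingly estimated at 40 nM, between 12 nM and 150 nM.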

Compound 3, inhibition constant: 46 nM
Beside the measured number, compound 3's estimate is 1.2-fold (0.06 log units) below it, and the stated range covers the measured number.
By their numbers in this assay, from the lowest: compound 2; then compounds 1 and 3 (each within the scatter of the next).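

In this assay, neopentyl in place of cyclohexyl on a saturated chain carbon bound to an amide-type nitrogen and a carbonyl carbon gives a 2.0-fold higher number from compound 1 to compound 3 (0.30 log units; within the scatter). At this position, then, the six-membered carbon ring can give way to a group with no ring while the read-out stays within the scatter. Nothing at hand gives a reason for this result.

As far as these compounds go, whether an amine or a carboxylic acid at this position would hold the read-out equally well remains open. So does whether neopentyl would behave the same way on the core of compound 2.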